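Two Weak Antiproliferative Thioureas and an Untested Relative

The compounds below may be only part of what the source reports. "The series", "measured", "known", "first", "only" and "open" are said of these compounds alone.

compound 1, `COc1ccccc1NC(=S)N/N=C/c1ccc2ccccc2n1`: 91700 nM
compound 2, `NC(=S)N/N=C/c1nc2ccccc2s1`: > 100000 nM

Among the measured compounds shown here, in a functional assay on HL-60 cells (Homo sapiens) for antiproliferative activity, read by sulforhodamine B assay, with a stated time of 72 h (a lower number here means a stronger inhibitor, a higher number a weaker inhibitor), compound 1 gives 91700 nM, the only actual number in this set. For compound 2 this assay returns only a limit, > 100000 nM, so its potency is not pinned down; this is the limit of > 100000 nM in this assay, at which 1 of the 2 values shown sits. Compound 1 therefore stands as a weak inhibitor, with no measured neighbour against which to gauge the effect of a single change.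

Compound 3, `S=C(N/N=C/c1ccc2ccccc2n1)Nc1ccc(Cl)cc1`, has not yet been tested. It differs from compound 1 in one place: 4-chlorophenyl in place of 2-methoxyphenyl on an amide-type nitrogen. For the measured compounds named here, since no pair of measured compounds differing in one place is available, the size of the step in this assay cannot be read from the data; a modest shift, plausibly within the scatter, is expected. Compound 3 is estimated to give 70000 nM, within a range of 25000 nM to 200000 nM. The expected step, a 1.3-fold lower number from compound 1 to compound 3 (0.12 log units; within the scatter), is estimated to stay within the usual scatter.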

Compound 3, half-maximal inhibitory concentration: > 100000 nM
Compound 3 gave a limit, no number (the forecaster's own chance of this, stated with the estimate: 35%); middle value at least 1.4-fold (0.15 log units) from the limit.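

In this assay compound 3 returns only a limit, > 100000 nM, and such limits now make up most of this small set: the limit of > 100000 nM in this assay, at which 2 of the 3 values shown sit. Placing 4-chlorophenyl in place of 2-methoxyphenyl on an amide-type nitrogen gives the first readable step at this position, an at least 1.0-fold higher number from compound 1 to compound 3 (0.03 log units; that floor lies within the scatter). That step is only a floor, so its full size cannot be read, but the change gives no sign of a stronger inhibitor.

On these data alone, whether any other group on this nitrogen would give a clearly lower number remains open, for example a phenyl ring carrying a carboxylic acid or an amine. One exchange also cannot show whether this position matters for activity against these cells.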